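Trimming a dodecyl stretch from compound 2

The source may hold more compounds than are shown below. What is called first, only, known or untested is meant among the compounds shown, and "the series" means these compounds.

Compound 1 `C/C=C1/[C@H](O[C@@H]2O[C@H](CO)[C@@H](O)[C@H](O)[C@H]2O)OC=C(C(=O)OC)[C@H]1CC(=O)OCCCCCCCCCCCCCCC`: 2000 nM
Compound 2 `C/C=C1/[C@H](O[C@@H]2O[C@H](COC(C)=O)[C@@H](OC(C)=O)[C@H](OC(C)=O)[C@H]2OC(C)=O)OC=C(C(=O)OC)[C@H]1CC(=O)OCCCCCCCCCCCCCCC`: 9660 nM

In a functional assay on MCF7 cells (Homo sapiens) for antiproliferative activity, read by MTT assay, with a stated time of 72 h (a higher number here means a weaker inhibitor, a lower number a stronger inhibitor), compound 2 has the higher number of the two and is the weaker inhibitor, with a gap to compound 1 that lies beyond the usual scatter. Compound 3 `C/C=C1/[C@H](O[C@@H]2O[C@H](COC(C)=O)[C@@H](OC(C)=O)[C@H](OC(C)=O)[C@H]2OC(C)=O)OC=C(C(=O)OC)[C@H]1CC(=O)OCCC` alters compound 2 in one place, by hydrogen in place of dodecyl on a saturated chain carbon, three bonds along the chain from an oxygen next to a carbonyl group with hydrogen in place of dodecyl on a saturated chain carbon, three bonds along the chain from an oxygen next to a carbonyl group. Going by the values given here, no measured pair shows this change alone, so any forecast is loose. A modest weakening is expected in this assay with an estimated 2.3-fold higher number from compound 2 to compound 3 (0.36 log units; beyond the scatter) and a wide margin. Estimated for compound 3 is 22000 nM with 6000 nM to 70000 nM as the expected range.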

Compound 3, half-maximal inhibitory concentration: 15000 nM
The estimate for compound 3 lay 1.5-fold (0.17 log units) above the measured number; low and high end bracket the measured number.
By their numbers in this assay, from the lowest: compound 1; then compounds 2 and 3 (each within the scatter of the next).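

The step of a 1.6-fold higher number from compound 2 to compound 3 (0.19 log units; within the scatter) in this assay lies within the usual scatter, so the two compounds cannot be told apart. At this saturated chain carbon, the dodecyl stretch can therefore give way to hydrogen without a readable effect on the antiproliferative reading, at least with the rest of compound 2 kept as it is. No measurement shown here offers an explanation for this result.

As far as these compounds go, whether the same swap on compound 1 would read alike remains open. So does what an amine or a carboxylic acid would give at this carbon.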